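Swapping a benzyl arm for phenyl on the shared core

This account rests on a few compounds, and the source may have more. Where it says the series, first, only, none or still open, it means among the compounds named here.

Compound 1 `COc1cccc(CNCCCNc2ccnc3cc(Cc4ccc(F)cc4)ccc23)c1O` and compound 2 `COc1ccc(F)cc1CNCCCNc1ccnc2cc(Cc3ccc(F)cc3)ccc12` share one core and differ only in the aromatic group carried on a saturated chain carbon bound to an amine nitrogen. In an ADME assay for permeability, using PAMPA, with a stated time of 30 min, at pH 7.4 (on this read-out higher numbers stand for higher permeability and lower numbers for lower permeability), compound 1 gives 23 10^-6 cm/s, and compound 2 gives 23 10^-6 cm/s; the step of no change at the digits printed from compound 1 to compound 2 (within the scatter) shows that this exchange left the read-out where it was. On the numbers shown, compound 1 therefore stands level with compound 2.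

Compound 3 `COc1cccc(CNCCCNc2ccnc3cc(-c4ccccc4)ccc23)c1O` is reached from compound 1 by a change at a different part of the molecule: phenyl in place of 4-fluorobenzyl on an aromatic carbon. Among the compounds with values here, no measured step touches that part of the core. Within the data shown here, the only step available, from compound 1 to compound 2, concerns a different aromatic group and was flat, so it gives no direct guide to the size of the step to be expected here. Without such a guide, the expected step of a 1.2-fold lower number from compound 1 to compound 3 (0.06 log units; within the scatter) is taken to be no change beyond the scatter. Compound 3 is thus estimated to give 20 10^-6 cm/s in this assay, with a range from 10 10^-6 cm/s to 40 10^-6 cm/s.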

Compound 3, apparent permeability: 237 10^-6 cm/s
For compound 3 the middle estimate is 12-fold (1.07 log units) below the measured one, outside the stated range (above it).
By their numbers in this assay, from the lowest: compounds 1 and 2 (each within the scatter of the next); then compound 3.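

At this position on the shared core, the read-out of this assay responds strongly: replacing 4-fluorobenzyl with phenyl gives a 10-fold higher number from compound 1 to compound 3 (1.01 log units; beyond the scatter), whereas the earlier exchange of the aromatic group on the chain gave no change at the digits printed from compound 1 to compound 2 (within the scatter). The two groups are alike in what can be counted: each holds one six-membered aromatic ring of carbon only and neither has a hydrogen-bond donor or acceptor. In this exchange, 8 heavy atoms, including one fluorine, are replaced by 6 carbon atoms. No measurement is available that explains this rise.

The change removes the fluorine and the carbon joining the ring to the core together, so benzyl or 4-fluorophenyl at this position would be needed to tell which of the two goes with the rise. On these data alone, it also remains open whether phenyl gives a similar step when the chain carries the 5-fluoro-2-methoxyphenyl group of compound 2, and whether a ring bearing an amine or a carboxylic acid at this position would keep the number as high.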